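What One Methyl Fewer May Do to Compound 2

A few compounds are considered here, and "the series" means these few. Any claim that something is new, unique, unknown or untested is made for them only; others in the source may bear on it.

Measured so far in a physicochemical assay for lipophilicity, at pH 7.4; on this read-out lower numbers stand for lower lipophilicity and higher numbers for higher lipophilicity:
compound 1 `CC(C)CN(c1ccc(C(C)(C)C)cc1)S(=O)(=O)c1ccc2c(c1)C(=O)CC(C1CCOCC1)O2` gives 4.97
compound 2 `CCc1ccc(N(CC(C)C)S(=O)(=O)c2ccc3c(c2)C(=O)CC(C2(C)CCOCC2)O3)cc1` gives 4.71

Compound 2 and compound 1 lie within the usual scatter of each other, so the two stand level in this assay and no order can be read from them. They also differ in more than one place, so no single structural change has yet been measured on its own.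

Compound 3 `CCc1ccc(N(CC(C)C)S(=O)(=O)c2ccc3c(c2)C(=O)CC(C2CCOCC2)O3)cc1` has not been measured. It differs from compound 2 in one place only, with hydrogen in place of methyl on a saturated ring carbon, so that 4-methyloxan-4-yl becomes oxan-4-yl. The expectation starts from compound 2 at 4.71 and rests on how little changes, since a single methyl leaves and the rest of the structure stays the same. A small downward move is expected, close in size to the usual scatter, and the estimate means a number 0.31 log units lower from compound 2 to compound 3 (beyond the scatter) in all. Compound 3 is estimated at 4.4 on this assay with a range from 4.1 to 4.7 expected.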

Compound 3, distribution coefficient: 4.21
Compound 3: the middle estimate sits 0.19 log units above what was measured; measured number inside the range.
By their numbers in this assay, from the lowest: compound 3; then compounds 2 and 1 (each within the scatter of the next).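

In this assay, the change from 4-methyloxan-4-yl to oxan-4-yl gives a number 0.50 log units lower from compound 2 to compound 3 (beyond the scatter), so the loss of this single methyl, on a saturated ring carbon three ring bonds from the ring oxygen, now has a measured size of its own. Compound 3 also links to compound 1 through one other change, ethyl in place of tert-butyl on an aromatic carbon, which gives a number 0.76 log units lower from compound 1 to compound 3 (beyond the scatter), so two separate single changes can now be read where compounds 1 and 2 alone, differing in more than one place, allowed neither. Nothing at hand explains either step.

From the compounds shown here alone, each step rests on one pair of compounds, so whether the methyl step would repeat with tert-butyl rather than ethyl on the aromatic carbon stays open. Going by these compounds, at the saturated ring carbon only methyl and hydrogen appear, and at the aromatic carbon only tert-butyl and ethyl, so what a hydroxyl group at the first place or an amine or a carboxylic acid at the second would do in this assay also stays open.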